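The source may hold more compounds than are shown below. What is called first, only, known or untested is meant among the compounds shown, and "the series" means these compounds.

Working notes on the series. Compound 2 `CC(C)(C)Oc1cc(-c2ccnc(N)n2)cc2[nH]nc(N)c12` stands highest of the three compounds measured in a physicochemical assay for solubility, read by LC-MS, in phosphate buffer, measured as kinetic solubility, with a stated time of 24 h, at 25 degrees C, at pH 7.4; a lower number here means a less soluble compound, a higher number a more soluble compound; compound 2 gives 68000 nM. Compound 1 `Nc1nccc(-c2ccc3c(NCc4ccccc4)n[nH]c3c2)n1` gives 17000 nM in this assay, and compound 3 `Nc1nccc(-c2ccc3c(Nc4ccccc4)n[nH]c3c2)n1` gives 3000 nM. Within the data shown here, the only measured step between two compounds that differ in one place is a 5.7-fold lower number from compound 1 to compound 3 (0.75 log units; beyond the scatter); it concerns a group on a nitrogen rather than the tert-butoxy of compound 2, and so it bears only loosely on the present change.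

Compound 4 `CC(C)Oc1cc(-c2ccnc(N)n2)cc2[nH]nc(N)c12` differs from compound 2 as follows: hydrogen in place of methyl on a saturated chain carbon bound to an oxygen on an aromatic ring and two saturated chain carbons. The change is the loss of a methyl from the chain and leaves every ring untouched. Among the measured compounds shown here, no measured pair shows a change of this kind, so the expectation rests on the small extent of the difference rather than on a precedent. A step within the usual scatter is expected, with a slightly higher number if anything, given that compound 2 already holds the highest value at 68000 nM. The step expected from compound 2 to compound 4 is a 1.2-fold higher number from compound 2 to compound 4 (0.07 log units; within the scatter). Compound 4 is therefore estimated at 80000 nM, with a range from 35000 nM to 200000 nM.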

Compound 4, solubility: 354000 nM
Estimate against measurement, compound 4: 4.4-fold (0.65 log units) below, outside the stated range (above it).
By their numbers in this assay, from the lowest: compound 3; then compound 1; then compound 2; then compound 4.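

On the saturated chain carbon bound to an oxygen on an aromatic ring, hydrogen in place of methyl (tert-butoxy to isopropoxy) gives a 5.2-fold higher number from compound 2 to compound 4 (0.72 log units; beyond the scatter) in this assay for this pair. Among these compounds, this is the first measured change in this chain, and it shows that the loss of a single methyl, with every ring untouched and no hydrogen-bond donor or acceptor among the atoms that leave, is enough to carry the number beyond the scatter; until now, the only step between two compounds differing in one place was phenyl in place of benzyl on a nitrogen, which went the other way, with a 5.7-fold lower number from compound 1 to compound 3 (0.75 log units; beyond the scatter) in that pair. Nothing available here bears on what lies behind the step from tert-butoxy to isopropoxy.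

One pair cannot tell whether the number keeps moving in the same direction as the chain is shortened further, to an ethoxy or a methoxy group, or what a hydroxyl or a cyclopropoxy group would give in this place. On these data alone, whether the same step would appear on a different core also remains open, since compound 1 and compound 3 carry no such chain.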